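The compounds below may be only part of what the source reports. "The series", "measured", "known", "first", "only" and "open" are said of these compounds alone.

Measured so far:
compound 1 `O=C(NCc1ccc(CNS(=O)(=O)c2cccc(F)c2)cc1)c1cccnc1` — 1000 nM
compound 2 `Cc1ccccc1C(=O)NCc1ccc(CNS(=O)(=O)c2cccc3ccccc23)cc1` — 100 nM

Among the compounds with values here, in an assay on MDA-MB-231 cells for displacement of a labelled ligand from C-X-C chemokine receptor type 4 (Homo sapiens), read by fluorescence and microscopy, with stated times of 10 min and 30 min (on this read-out higher numbers stand for an effect only at larger amounts of compound and lower numbers for an effect already at smaller amounts), compound 2 gives the lowest of the two numbers so far; compound 1 gives a number that is higher by a gap beyond the scatter. Compound 3 `Cc1ccccc1C(=O)NCc1ccc(CNS(=O)(=O)c2cccc(F)c2)cc1` carries 3-fluorophenyl in place of naphthalen-1-yl on a sulfonyl sulfur. Within the data shown here, no single-point step between measured compounds exists, so the size of this change cannot be read off directly; compound 1, which also carries the 3-fluorophenyl, shows only that this group is compatible with the weaker of the two values. A moderate rise, beyond the scatter, is expected, a 4.0-fold higher number from compound 2 to compound 3 (0.60 log units; beyond the scatter). For compound 3 the estimate is 400 nM, within 150 nM to 1500 nM.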

Compound 3, effective concentration (reported as EC, without a stated level of effect): 100 nM
Compound 3: the middle estimate sits 4.0-fold (0.60 log units) above what was measured; measured number below the stated range.
By their numbers in this assay, from the lowest: compounds 2 and 3 (each within the scatter of the next); then compound 1.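

On the sulfonyl sulfur, 3-fluorophenyl and naphthalen-1-yl are not told apart in this assay, with no change at the digits printed from compound 2 to compound 3 (within the scatter) for this change. The carbonyl carbon is the position with a step beyond the scatter, a 10-fold lower number from compound 1 to compound 3 (1.00 log units; beyond the scatter) with 2-methylphenyl in place of pyridin-3-yl. No measurement on hand explains either step.

Open, going by these compounds, is whether a carboxylic acid or an aminomethyl group on the carbonyl carbon's ring would keep the value of compound 3. Also open, on these data alone, is whether a pyridin-3-yl step of similar size would appear alongside naphthalen-1-yl.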